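A few compounds are considered here, and "the series" means these few. Any claim that something is new, unique, unknown or untested is made for them only; others in the source may bear on it.

Working notes on the series in an ADME assay on Vero cells (Chlorocebus sabaeus) for cytotoxicity, read by MTT assay, with a stated time of 96 h; a lower number here means that less compound is tolerated, a higher number that more compound is tolerated. Compound 1 `C/C(=N\NC(N)=O)c1ccc2[nH]c(-c3ccc(Cl)cc3)nc2c1` gives > 100000 nM, which is a limit of the assay and not a number. Compound 2 `C/C(=N\NC(N)=S)c1ccc2[nH]c(-c3ccccc3)nc2c1` gives > 100000 nM, also a limit and not a number, so compound 2 has no exact position in the series. All that can be said so far is the limit of > 100000 nM in this assay, at which 2 of the 2 values shown sit.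

Compound 3 `C/C(=N\NC(N)=S)c1ccc2[nH]c(-c3ccc(Cl)cc3)nc2c1` has chloro in place of hydrogen on an aromatic carbon of compound 2, para to a large group, which turns phenyl into 4-chlorophenyl: chloro in place of hydrogen on an aromatic carbon. No measured step sizes this change in this assay. Compound 1 also carries 4-chlorophenyl and gives > 100000 nM, a limit, so no large fall is expected. The expected size of an at least 1.1-fold lower number from compound 2 to compound 3 (0.04 log units; that floor lies within the scatter) is none beyond the scatter. For compound 3 the estimated value is 90000 nM, with an expected range of 35000 nM to 100000 nM.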

Compound 3, half-maximal cytotoxic concentration: > 100000 nM
Compound 3: no number, only a limit; the forecaster's own chance of this, stated with the estimate: 65%; middle value at least 1.1-fold (0.04 log units) from the limit.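

Compound 3 gives > 100000 nM, a limit and not a number, so the steps to it from compound 1 and compound 2 cannot be read. What stays open is how compound 1, compound 2 and compound 3 actually differ: the limit of > 100000 nM in this assay, at which 3 of the 3 values shown sit.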